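Hydroxy to Chloro: Expected Cytotoxicity of Compound 4

The source may report more compounds than this note shows. Statements on the series, on what has been measured and on what is new or still open speak of the compounds shown alone.

Measured so far in an ADME assay on A549 cells (Homo sapiens) for cytotoxicity, read by MTT assay, with a stated time of 48 h; on this read-out lower numbers stand for stronger inhibition of growth and higher numbers for weaker inhibition of growth:
compound 1, `O=C(/C=C\c1ccccc1O)N1N=C(c2ccncc2)OC1c1c[nH]c2ccccc12`: > 30 ug/mL
compound 2, `O=C(/C=C\c1cccc(O)c1)N1N=C(c2ccncc2)OC1c1c[nH]c2ccccc12`: > 30 ug/mL
compound 3, `O=C(/C=C\c1ccc([N+](=O)[O-])cc1)N1N=C(c2ccncc2)OC1c1c[nH]c2ccccc12`: > 30 ug/mL

Compound 1 carries a 2-hydroxyphenyl on a double-bonded chain carbon bound to a double-bonded chain carbon. In this assay compound 1 gives > 30 ug/mL, and this is a limit of the assay, not a number. For compound 2 the value > 30 ug/mL is again a limit. For compound 3 the value > 30 ug/mL is also a limit. Compound 1 thus stands exactly where every measured compound stands: the limit of > 30 ug/mL in this assay, at which 3 of the 3 values shown sit. As a result the steps a step that the two limits leave unreadable from compound 1 to compound 2, a step that the two limits leave unreadable from compound 1 to compound 3 and a step that the two limits leave unreadable from compound 2 to compound 3 cannot be sized in either direction.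

Compound 4 `O=C(/C=C\c1ccccc1Cl)N1N=C(c2ccncc2)OC1c1c[nH]c2ccccc12` differs from compound 1 in one place: chloro in place of hydroxy on an aromatic carbon. Going by the values given here, none of the measured steps touches this kind of change; each of them swaps one whole aryl group for another, and each is unreadable. Among the compounds with values here, the only guide is the limit of > 30 ug/mL in this assay, at which 3 of the 3 values shown sit, which makes a further value at the limit the most likely outcome. In this assay compound 4 is therefore expected to show a step that the limit leaves unreadable from compound 1 to compound 4, meaning no step beyond the scatter. The estimate for compound 4 is 40 ug/mL, with an expected range from 20 ug/mL to 120 ug/mL, and most probably the assay would again report only a limit.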

Compound 4, concentration for 50% growth inhibition: > 30 ug/mL
Compound 4: no number, only a limit (the forecaster's own chance of this, stated with the estimate: 80%); the middle value does not contradict the limit.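

In this assay compound 4 gives > 30 ug/mL, which is a limit of the assay and not a number. Its steps from compound 1, compound 2 and compound 3 cannot be read, so no new step emerges: the limit of > 30 ug/mL in this assay, at which 4 of the 4 values shown sit.

The compounds shown leave open how strongly any of the four inhibits growth, and whether chloro in place of hydroxy makes any difference.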